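Replacing the 4-fluorobenzyl ether of compound 1 with ethyl

The source may hold more compounds than are shown below. What is called first, only, known or untested is meant among the compounds shown, and "the series" means these compounds.

Measured so far:
compound 1 `CN(C)CCNc1ccnc2cc(OCc3ccc(F)cc3)ccc12`: 890 nM
compound 2 `CC(C)COc1ccc2c(Cl)ccnc2c1`: 3030 nM
compound 3 `CN(C)CCCNc1ccnc2cc(OCc3ccc(F)cc3)ccc12`: 490 nM

In a functional assay on BGC-823 cells (Homo sapiens) for cytotoxicity, read by MTT assay, with a stated time of 48 h (on this read-out lower numbers stand for stronger inhibition and higher numbers for weaker inhibition), compound 1 stands second highest of the three numbers; compound 3 sits within the scatter of it, and compound 2 lies beyond the scatter with the higher value. Compound 4 `CCOc1ccc2c(NCCN(C)C)ccnc2c1` differs from compound 1 in one place: methyl in place of 4-fluorophenyl on a saturated chain carbon bound to an oxygen on an aromatic ring; cut one bond further out, the change reads 4-fluorobenzyl to ethyl. Among the measured compounds shown here, the single measured step, a 1.8-fold lower number from compound 1 to compound 3 (0.26 log units; within the scatter), concerns the amine chain and not the ether, so it does not bear on this exchange. For the measured compounds named here, no measured pair tests the ether directly. Compound 4 is expected to give 2500 nM, within a range from 800 nM to 8000 nM. The step expected is a 2.8-fold higher number from compound 1 to compound 4 (0.45 log units; beyond the scatter).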

Compound 4, half-maximal inhibitory concentration: 2520 nM
Estimate against measurement, compound 4: 1.0-fold (0.00 log units) below; the range from low to high includes it.
By their numbers in this assay, from the lowest: compounds 3 and 1 (each within the scatter of the next); then compounds 4 and 2 (each within the scatter of the next).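

In this assay the ether position responds to change: the exchange of 4-fluorobenzyl for ethyl gives a 2.8-fold higher number from compound 1 to compound 4 (0.45 log units; beyond the scatter), a modest step but the first measured at this place. Losing the 4-fluorophenyl therefore weakens inhibition without abolishing it, whereas the earlier step concerned only the amine chain. Nothing available explains this step. The compounds shown leave open whether the aromatic ring, its fluorine or simply the chain length matters. A plain benzyl ether or a butyl ether at this place would help separate these possibilities.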